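This account rests on a few compounds, and the source may have more. Where it says the series, first, only, none or still open, it means among the compounds named here.

In an in vitro ADME assay on microsomes from liver (Mus musculus) for pharmacokinetics, read by LC-MS, with a stated time of 10 min, tested at 1 uM (a lower number here means slower removal, a higher number faster removal of the compound), compound 1 `CN1C[C@H](C(=O)Nc2cccc(F)c2)[C@@H](c2ccc(/C=C/C(=O)Nc3ccccc3N)cc2)C1` gives 56 mL/min/kg, compound 2 `CN1C[C@H](C(=O)Nc2cccc(Cl)c2)[C@@H](c2ccc(/C=C/C(=O)Nc3ccccc3N)cc2)C1` gives 58 mL/min/kg and compound 3 `COc1cccc(NC(=O)[C@H]2CN(C)C[C@@H]2c2ccc(/C=C/C(=O)Nc3ccccc3N)cc2)c1` gives 65 mL/min/kg, so compound 3 stands level with the other two, within the scatter. Compound 4 `CN1C[C@H](C(=O)Nc2ccc(Cl)c(Cl)c2)[C@@H](c2ccc(/C=C/C(=O)Nc3ccccc3N)cc2)C1` differs from it as follows: 3,4-dichlorophenyl in place of 3-methoxyphenyl on an amide-type nitrogen. In words, this is 3,4-dichlorophenyl in place of 3-methoxyphenyl on an amide-type nitrogen. The nearest measured evidence is the exchange of single groups on an aromatic carbon: a 1.0-fold higher number from compound 1 to compound 2 (0.02 log units; within the scatter), a 1.2-fold higher number from compound 1 to compound 3 (0.06 log units; within the scatter) and a 1.1-fold higher number from compound 2 to compound 3 (0.05 log units; within the scatter), all within the scatter. None of these steps covers the 3,4-dichlorophenyl group itself, hence the wide range. The expected step is a 1.0-fold lower number from compound 3 to compound 4 (0.02 log units; within the scatter), with no change expected beyond the scatter. For compound 4 the estimated value is 62 mL/min/kg, with an expected range of 38 mL/min/kg to 95 mL/min/kg.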

Compound 4, clearance: 36 mL/min/kg
Beside the measured number, compound 4's estimate is 1.7-fold (0.24 log units) above it; measured number below the stated range.
By their numbers in this assay, from the lowest: compounds 4, 1, 2 and 3 (each within the scatter of the next).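

In this assay the second chlorine gives a 1.6-fold lower number from compound 2 to compound 4 (0.21 log units; within the scatter) and the 3,4-dichlorophenyl exchanges give a 1.8-fold lower number from compound 3 to compound 4 (0.26 log units; within the scatter) and a 1.6-fold lower number from compound 1 to compound 4 (0.19 log units; within the scatter) with all three steps within the scatter. The aromatic group on the amide-type nitrogen can therefore carry two chlorines, not just one group, without a change beyond the scatter. No supporting measurement bears on this result.

As far as these compounds go, whether an amine or a carboxylic acid on this ring would shift clearance beyond the scatter remains open. So does the effect of a longer chain in place of the ring.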